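This account rests on a few compounds, and the source may have more. Where it says the series, first, only, none or still open, it means among the compounds named here.

Compound 1 `CCN(CC)CN1C(=O)/C(=N/NC(=S)Nc2ccc(Cl)cc2)c2ccccc21`: 7600 nM
Compound 2 `CCN(CC)CN1C(=O)/C(=N/NC(=S)Nc2ccc(C)cc2)c2cc(Cl)ccc21`: 8600 nM

In a functional assay on HeLa cells (Homo sapiens) for inhibition, read by cell counting, with a stated time of 96 h (on this read-out higher numbers stand for weaker inhibition and lower numbers for stronger inhibition), compound 2 gives 8600 nM, which lies within the scatter of compound 1 at 7600 nM. Compound 3 `CCN(CC)CN1C(=O)/C(=N/NC(=S)Nc2ccc(Cl)cc2)c2cc(Cl)ccc21` follows from compound 2 by one change, chloro in place of methyl on an aromatic carbon. Among the measured compounds shown here, no measured pair isolates this change. Compound 1, which also carries 4-chlorophenyl, gives 7600 nM, so no large shift is expected in this assay. The expected step, a 1.3-fold lower number from compound 2 to compound 3 (0.12 log units; within the scatter), stays within the scatter. For compound 3 the estimated value is 6500 nM, with an expected range of 2800 nM to 14000 nM.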

Compound 3, half-maximal inhibitory concentration: > 125000 nM
Compound 3 was reported as a limit; the forecaster's own chance of this, stated with the estimate: 5%; middle value at least 19-fold (1.28 log units) away from the limit.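

Compound 3 is reported as a limit of the assay, not as a number: the limit of > 125000 nM in this assay, at which 1 of the 3 values shown sits. In this assay, the change from 4-methylphenyl to 4-chlorophenyl gives an at least 14-fold higher number from compound 2 to compound 3 (1.16 log units; beyond the scatter), and a further chloro on the shared core, with 4-chlorophenyl kept, gives an at least 16-fold higher number from compound 1 to compound 3 (1.21 log units; beyond the scatter). Compounds 1 and 2 each carry a single chloro and sit within the scatter of each other, so only compound 3 shows that the two chloro groups together go with a large loss. As far as these compounds go, it remains open whether a bromo or a methoxy group at this position would behave like chloro or like methyl.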